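This account rests on a few compounds, and the source may have more. Where it says the series, first, only, none or still open, it means among the compounds named here.

Measured so far:
compound 1 `CN(Cc1ccc(C(=O)O)cc1)c1ccc(OCc2c(-c3c(Cl)cccc3Cl)noc2C2CC2)nc1C(F)(F)F` – 30 nM
compound 2 `O=C(O)c1cccc(OCc2ccc(OCc3c(-c4c(Cl)cccc4Cl)noc3C3CC3)nc2C(F)(F)F)c1` – 151 nM

Both values come from a functional assay on HEK293 cells for agonist activity at Bile acid receptor (Homo sapiens); a lower number here means that less compound is needed, a higher number that more compound is needed for the effect. Going by the values given here, compound 2 stands at the higher of the two numbers; its only neighbour is compound 1, and the step of a 5.0-fold higher number from compound 1 to compound 2 (0.70 log units; beyond the scatter) goes beyond the scatter.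

Compound 3 `CC(Oc1ccc(C(=O)O)cc1)c1ccc(OCc2c(-c3c(Cl)cccc3Cl)noc2C2CC2)nc1C(F)(F)F` has not been measured. It differs from compound 2 in one place: 1-(4-carboxyphenoxy)ethyl in place of (3-carboxyphenoxy)methyl on an aromatic carbon. The new group, 1-(4-carboxyphenoxy)ethyl, carries its carboxylic acid where compound 1 carries its own, while the ether link of compound 2 is kept and gains one more carbon.

Among the compounds with values here, only one measured step bears on this change, and it is an indirect one: a 5.0-fold higher number from compound 1 to compound 2 (0.70 log units; beyond the scatter) moved the acid and swapped the linker at once. The two changes cannot be told apart within that single step. Taking it as a partial guide, compound 3 is expected to return toward compound 1, giving a step of a 2.5-fold lower number from compound 2 to compound 3 (0.40 log units; beyond the scatter) in this assay, a lower number, though the added carbon leaves the size uncertain. The estimate for compound 3 is 60 nM, within 20 nM to 200 nM.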

Compound 3, half-maximal effective concentration: 189 nM
Estimate against measurement, compound 3: 3.2-fold (0.50 log units) below, and the stated range covers the measured number.
By their numbers in this assay, from the lowest: compound 1; then compounds 2 and 3 (each within the scatter of the next).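

In this assay, putting 1-(4-carboxyphenoxy)ethyl in place of (3-carboxyphenoxy)methyl on this aromatic carbon gives a 1.3-fold higher number from compound 2 to compound 3 (0.10 log units; within the scatter), so this change makes no difference that can be told from the scatter. The gap to the best-placed compound remains, with a 6.3-fold higher number from compound 1 to compound 3 (0.80 log units; beyond the scatter), so among these three compounds a 4-carboxy arrangement on an oxygen-linked group does not by itself match the number of compound 1, which carries (4-carboxybenzyl)(methyl)amino at this position. Nothing measured here explains why the nitrogen-linked group stands apart from the two oxygen-linked ones.

The step from compound 2 to compound 3 moves the carboxylic acid and adds a carbon at once, so two effects of opposite direction could hide inside it, and the plain (4-carboxyphenoxy)methyl group would be needed to separate them. Equally open, going by these compounds, is whether the methylamino link itself carries the lower number of compound 1, a question that (3-carboxybenzyl)(methyl)amino, with the acid moved and the nitrogen link kept, would address.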